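The source may hold more compounds than are shown below. What is called first, only, known or untested is meant among the compounds shown, and "the series" means these compounds.

Measured in a functional assay on MCF7 cells (Homo sapiens) for antiproliferative activity, with a stated time of 72 h; on this read-out higher numbers stand for weaker inhibition and lower numbers for stronger inhibition:

compound 1 `COc1ccc(C2CC(c3ccc(Cl)cc3)=NN2c2nc(-c3ccccc3)c(C#N)c(=O)n2C)cc1`: 4800 nM
compound 2 `COc1ccc(C2=NN(c3nc(-c4ccccc4)c(C#N)c(=O)n3C)C(c3ccc(OC)cc3)C2)cc1`: 127000 nM
compound 3 `Cn1c(N2N=C(c3ccccc3)CC2c2ccc(Cl)cc2)nc(-c2ccc(Cl)cc2)c(C#N)c1=O`: 46300 nM

One single-point change is available within this set, (methoxy in place of chloro on an aromatic carbon), and it gave a 26-fold higher number from compound 1 to compound 2 (1.42 log units; beyond the scatter). Compound 3 carries a different core; the difference between the core of compound 1 and the core of compound 3 is not broken down here. Compound 3 sits between compound 1 and compound 2, and its two values show it weaker than compound 1 and stronger than compound 2.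

Compound 4 `COc1ccc(C2CC(c3ccccc3)=NN2c2nc(-c3ccc(Cl)cc3)c(C#N)c(=O)n2C)cc1` has not yet been run in this assay. It stands to compound 3 as compound 2 stands to compound 1: methoxy in place of chloro on an aromatic carbon. The place lines of the two changes read the same word for word, so this is the same change on a second core. Within the data shown here, the expected step of a 5.4-fold higher number from compound 3 to compound 4 (0.73 log units; beyond the scatter) rests on the earlier step of a 26-fold higher number from compound 1 to compound 2 (1.42 log units; beyond the scatter), tempered by the fact that only one such pair exists and compound 3 already sits far to the weak side. Compound 4 is therefore expected at about 250000 nM, with a plausible range from 60000 nM to 1000000 nM.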

Compound 4, half-maximal inhibitory concentration: 52400 nM
Estimate against measurement, compound 4: 4.8-fold (0.68 log units) above; measured number below the stated range.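

Carried to the second core in this assay, the change from 4-chlorophenyl to 4-methoxyphenyl gave a 1.1-fold higher number from compound 3 to compound 4 (0.05 log units; within the scatter), so on this core the two values cannot be told apart. The large step seen on the core of compound 1 therefore did not carry over, and the effect of this change depends on the core it sits on: the same change on two cores in this assay, a 26-fold higher number (1.42 log units; beyond the scatter) from compound 1 to compound 2 and a 1.1-fold higher number (0.05 log units; within the scatter) from compound 3 to compound 4, 23-fold (1.37 log units) apart, beyond the scatter of two such steps. This rests on a single pair for each core, so it does not show which structural difference between the cores accounts for the gap, nor how the change would behave on any further core.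

Open, from the compounds shown here alone, is whether an amine, a carboxylic acid or a longer chain in this place on an aromatic carbon would separate from chloro and methoxy on either core. Also open is whether the nitrile on the shared core contributes to the values seen, as it stays constant across all compounds shown.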